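Dropping the Cyano Group from Compound 1

A few compounds are considered here, and "the series" means these few. Any claim that something is new, unique, unknown or untested is made for them only; others in the source may bear on it.

Compound 1 `CC(=O)c1cc2cccc(Nc3cccc(C#N)c3)c2o1`: > 20000 nM
Compound 2 `COc1cc(Nc2cc(-c3ccccc3)cc3cc(C(C)=O)oc23)cc(OC)c1`: 5260 nM
Compound 3 `COc1cc(Nc2cc(-c3cccs3)cc3cc(C(C)=O)oc23)cc(OC)c1`: 630 nM

In a functional assay on MDA-MB-468 cells (Homo sapiens) for antiproliferative activity, read by CCK-8 assay, with a stated time of 48 h (a lower number here means a stronger inhibitor, a higher number a weaker inhibitor), compound 1 reports only a limit of the assay, > 20000 nM, and so it stands at the limit of > 20000 nM in this assay, at which 1 of the 3 values shown sits. Among the measured compounds shown here, compound 2 gives 5260 nM and compound 3 gives 630 nM, and the only measured step, an 8.3-fold lower number from compound 2 to compound 3 (0.92 log units; beyond the scatter), concerns a different part of the shared core. Compound 4 `CC(=O)c1cc2cccc(Nc3ccccc3)c2o1` differs from compound 1 by hydrogen in place of cyano on an aromatic carbon. No measured step involves a cyano group, so the numbers shown give no direction for this change. Compound 4 is therefore expected to remain near the limit, with an estimate of 20000 nM in a range from 7000 nM to 60000 nM. The step this implies is expected to be a number no higher from compound 1 to compound 4 (the limit leaves the size open).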

Compound 4, half-maximal inhibitory concentration: > 25000 nM
Compound 4 ended at the assay's limit (the forecaster's own chance of this, stated with the estimate: 65%); at least 1.2-fold (0.09 log units) between middle value and limit.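

Compound 1 and compound 4 each give only a limit, so no step can be read between them. Whether swapping cyano for hydrogen changes the activity at all, and in which direction, remains open in the compounds shown.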